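The compounds below may be only part of what the source reports. "The series", "measured", "known", "first", "only" and "open" are said of these compounds alone.

In a functional assay on PC-3 cells (Homo sapiens) for antiproliferative activity, read by MTT assay, with a stated time of 48 h (on this read-out higher numbers stand for weaker inhibition and lower numbers for stronger inhibition), compound 1 `CCn1c(C(=O)NCC#N)ccc1C(CC)(CC)c1ccc(OCCC(O)(CC)CC)c(C)c1` gives 17800 nM with cyanomethyl on the amide-type nitrogen. Compound 2 `CCn1c(C(=O)N(CCC#N)CCC#N)ccc1C(CC)(CC)c1ccc(OCCC(O)(CC)CC)c(C)c1` gives > 50000 nM and this is a limit. Compound 3 `CCn1c(C(=O)Nc2ccc(OC(F)(F)F)cc2)ccc1C(CC)(CC)c1ccc(OCCC(O)(CC)CC)c(C)c1` gives > 50000 nM and this too is a limit. Compound 3 therefore has no number of its own and stands at the limit of > 50000 nM in this assay, at which 2 of the 3 values shown sit, together with compound 2.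

The next change leads to compound 4 `CCC(C)C(NC(=O)c1ccc(C(CC)(CC)c2ccc(OCCC(O)(CC)CC)c(C)c2)n1CC)C(=O)OC` and is a group of 9 heavy atoms (7 carbon, 2 oxygen; no ring) in place of a group of 11 heavy atoms (7 carbon, 1 oxygen, 3 fluorine; one six-membered aromatic ring of carbon only), on an amide-type nitrogen with the shared core unchanged. The closest measured step is an at least 2.8-fold higher number from compound 1 to compound 3 (0.44 log units; beyond the scatter) and it concerns the same amide-type nitrogen. Also relevant is an at least 2.8-fold higher number from compound 1 to compound 2 (0.44 log units; beyond the scatter) at the same carbonyl carbon. Both give only bounds on size. The step that the two limits leave unreadable from compound 2 to compound 3 adds no size information.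

Removing 4-(trifluoromethoxy)phenyl could move the series back towards compound 1, which also has no ring in this group. Compound 2 goes against that reading, as its group also has no ring and yet it reaches the limit. A modest move towards stronger inhibition is therefore expected, with a fair chance of another limit. The expected step is an at least 1.6-fold lower number from compound 3 to compound 4 (0.22 log units; that floor lies within the scatter) and its size stays uncertain. The estimate for compound 4 is 30000 nM with an expected range of 12000 nM to 50000 nM in this assay terms.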

Compound 4, half-maximal inhibitory concentration: > 50000 nM
Compound 4: no number, only a limit (the forecaster's own chance of this, stated with the estimate: 45%); at least 1.6-fold (0.22 log units) between middle value and limit.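

In this assay compound 4 gives > 50000 nM, and this is a limit, not a number. On the amide-type nitrogen, a chain with no ring in place of 4-(trifluoromethoxy)phenyl still gives an at least 2.8-fold higher number from compound 1 to compound 4 (0.44 log units; beyond the scatter), so removing that ring does not by itself restore a measurable value like that of compound 1, while the steps among compound 2, compound 3 and compound 4 join two limits and cannot be read. Among these compounds, compound 1, with cyanomethyl, is now the only compound in the set with a number, and the other three stand together at one limit: the limit of > 50000 nM in this assay, at which 3 of the 4 values shown sit.

With three limits, the compounds shown cannot order compound 2, compound 3 and compound 4, nor tell whether the number of compound 1 depends on its nitrile or on its short chain. A carboxylic acid in place of the ester of compound 4, or an amine or a longer nitrile chain on the amide-type nitrogen, would be needed to show whether any other group on this nitrogen gives a number in this assay.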